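The compounds below may be only part of what the source reports. "The series", "measured", "known", "first", "only" and "open" are said of these compounds alone.

Compound 1 `COc1cc(C)cc(-c2nn(CC#N)cc2-c2ccnc(-c3ccc(N(C)C)cc3)c2)c1`: 363 nM
Compound 2 `COc1cc(C)cc(-c2nn(CC#N)cc2-c2ccc(-c3cccc(C(C)=O)c3)nc2)c1`: 3450 nM

In a functional assay on PC-3 cells (Homo sapiens) for inhibition, read by sulforhodamine B assay, with a stated time of 48 h (a lower number here means a stronger inhibitor of growth, a higher number a weaker inhibitor of growth), compound 1 gives 363 nM, the lowest of the two numbers, while compound 2 gives 3450 nM, a gap beyond the scatter. Compound 3 `Cc1cc(O)cc(-c2nn(CC#N)cc2-c2ccnc(-c3ccc(N(C)C)cc3)c2)c1` has not yet been measured. It differs from compound 1 in one place: hydrogen in place of methyl on an oxygen on an aromatic ring. No comparable change has been measured among these compounds, so the expected step is small and uncertain; the expected step is a 1.4-fold higher number from compound 1 to compound 3 (0.14 log units; within the scatter), probably within the scatter. Compound 3 is therefore estimated to give about 500 nM, between 150 nM and 1800 nM.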

Compound 3, concentration for 50% growth inhibition: 3770 nM
For compound 3 the middle estimate is 7.5-fold (0.88 log units) below the measured one; measured number above the stated range.
By their numbers in this assay, from the lowest: compound 1; then compounds 2 and 3 (each within the scatter of the next).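

In this assay the change from methoxy to hydroxy gives a 10-fold higher number from compound 1 to compound 3 (1.02 log units; beyond the scatter) and shows that this oxygen is not a place where the methyl can be lost freely. Removing a single carbon while the rest of the molecule stays the same moves the number beyond the scatter. Within the data shown here, this is the first step between compounds that differ in one place, and the data offered here give no explanation for its size. The compounds shown leave open whether ethoxy or a longer chain on this oxygen would match or improve on the methoxy of compound 1. They also leave open whether an amine in the same place would behave like hydroxy.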